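Methoxy to Trifluoromethyl: Expecting the Value of Compound 4

This account rests on a few compounds, and the source may have more. Where it says the series, first, only, none or still open, it means among the compounds named here.

Measured compounds:
compound 1, `CCOC(=O)c1c(-c2ccc(C(F)(F)F)cc2)csc1N`, gives 16% in an assay on isolated protein for inhibition of protein kinase C zeta type (Homo sapiens), with stated times of 1 h and 2.5 min, tested at 30 uM; a lower number here means less inhibition, a higher number more inhibition at the concentration tested (going by the name of the read-out)
compound 2, `Cc1ccc(-c2csc(N)c2C(=O)OCc2ccccc2)cc1`, gives 60% in this assay
compound 3, `COc1ccc(-c2csc(N)c2C(=O)OCc2ccccc2)cc1`, gives 86% in this assay

Compound 3 stands highest of the three numbers. Its nearest neighbour is compound 2, reached by the step of a number 26 percentage points higher from compound 2 to compound 3 (beyond the scatter), where methoxy in place of methyl on an aromatic carbon raised inhibition by a modest amount that is beyond the scatter. The furthest is compound 1, whose reading lies far below that of compound 3, though the two differ in more than one place.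

Compound 4, `Nc1scc(-c2ccc(C(F)(F)F)cc2)c1C(=O)OCc1ccccc1`, differs from compound 3 in one place: trifluoromethyl in place of methoxy on an aromatic carbon. Going by the values given here, only the step from compound 2 to compound 3 bears directly on this position, and it showed that a change of the group sitting para to the large group can move the read-out by a modest, real amount. Among the compounds with values here, no measured pair compares trifluoromethyl with methoxy on the same ester. Within the data shown here, compound 1 is the only compound carrying trifluoromethyl, and it gives 16%. It bears an ethyl ester rather than a benzyl ester, so its gap to compound 4 is not a clean step.

Taking the modest size of the methyl-to-methoxy step and the low reading of the one trifluoromethyl compound together, a decrease beyond the scatter is expected for compound 4, estimated as a number 41 percentage points lower from compound 3 to compound 4 (beyond the scatter). Compound 4 is therefore expected to give 45%, with a range from 15% to 75%.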

Compound 4, a percentage reported as inhibition, at one concentration (the size of the read-out at that concentration, not a potency): 21%
Beside the measured number, compound 4's estimate is 24 percentage points above it, and the stated range covers the measured number.
By their numbers in this assay, from the lowest: compounds 1 and 4 (each within the scatter of the next); then compound 2; then compound 3.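

With the benzyl ester held constant, the group on the aromatic ring now has three direct comparisons in this assay: trifluoromethyl in place of methoxy gives a number 65 percentage points lower from compound 3 to compound 4 (beyond the scatter), and trifluoromethyl in place of methyl gives a number 39 percentage points lower from compound 2 to compound 4 (beyond the scatter), both steps larger than the one seen earlier for methoxy in place of methyl, a number 26 percentage points higher from compound 2 to compound 3 (beyond the scatter). With trifluoromethyl in this place, phenyl in place of methyl on the ester chain gives a number 5 percentage points higher from compound 1 to compound 4 (within the scatter), so among the compounds carrying trifluoromethyl, the ethyl and benzyl esters are not told apart by this read-out. Nothing measured here accounts for the loss of inhibition on moving from methoxy to trifluoromethyl.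

The compounds shown leave open whether the ester would also make no difference with methoxy or methyl in this place, since both of those groups appear only on the benzyl ester. They also leave open how a hydroxyl, an amine or a chlorine on this aromatic carbon would fall relative to the three groups compared so far.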